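Chain extension from compound 2 to compound 3

This account rests on a few compounds, and the source may have more. Where it says the series, first, only, none or still open, it means among the compounds named here.

- Compound 1 `CCCCOc1cc(OC)c(Br)cc1C(C)=O` gives 56900000 nM in a functional assay, with a stated time of 10 min; on this read-out lower numbers stand for stronger inhibition and higher numbers for weaker inhibition
- Compound 2 `CCCCOc1cc(OC)ccc1C(C)=O` gives 57200000 nM in this assay

Going by the values given here, compound 2 stands level with compound 1, the only other measured compound in this assay (a 1.0-fold higher number from compound 1 to compound 2 (0.00 log units; within the scatter)). Compound 3 `CCCCCCCCOc1cc(OC)ccc1C(C)=O` differs from compound 2 on the chain: butyl in place of hydrogen on a saturated chain carbon, four bonds along the chain from an oxygen on an aromatic ring. Among the compounds with values here, the one measured step, hydrogen in place of bromo on an aromatic carbon, does not touch the chain and gives no size for this change, so the expectation is loose. For compound 3 a modest step toward stronger inhibition is expected (a 1.9-fold lower number from compound 2 to compound 3 (0.28 log units; within the scatter)). For compound 3 the estimated value is 30000000 nM (expected range 6000000 nM to 90000000 nM).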

Compound 3, half-maximal inhibitory concentration: 69400000 nM
Compound 3: middle estimate off by 2.3-fold (0.36 log units), on the low side, within the range that was stated.
By their numbers in this assay, from the lowest: compounds 1, 2 and 3 (each within the scatter of the next).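

Butyl in place of hydrogen at this chain position, four bonds along the chain from an oxygen on an aromatic ring, gives a 1.2-fold higher number from compound 2 to compound 3 (0.08 log units; within the scatter) in this assay. Going by these compounds alone, this is the first reading on the chain, and the added butyl does not separate compound 3 from compound 2 on this read-out. No available data bear on the reason for this result.

On these data alone, whether an amine or a carboxylic acid in place of butyl at this position would shift the read-out remains open. As far as these compounds go, the effect of a longer chain on the core of compound 1, which carries bromo, is also open.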